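A few compounds are considered here, and "the series" means these few. Any claim that something is new, unique, unknown or untested is made for them only; others in the source may bear on it.

Measured in an ADME assay for permeability, using PAMPA, with a stated time of 4 h; a lower number here means that the compound crosses the layer more slowly, a higher number that the compound crosses the layer faster:
- compound 1 `CN1CCNC(=O)COc2ccc(F)cc2C(=O)N2CCCC[C@H]2c2cc3nc(N4CC(O)C4)cc1n3n2`: 8 10^-6 cm/s
- compound 2 `CNC1CN(c2cc3n4nc(cc4n2)[C@@H]2CCCCN2C(=O)c2cc(F)ccc2OCC(=O)NCCN3C)C1`: 5.9 10^-6 cm/s

In this assay, among the measured compounds shown here, compound 2 stands at 5.9 10^-6 cm/s, and its only measured neighbour, compound 1, stands at 8 10^-6 cm/s. These two values lie within the scatter of each other. For the measured compounds named here, only two numbers are available, so they mark out a very narrow part of the scale.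

The next compound is compound 3 `CN1CCNC(=O)COc2ccc(F)cc2C(=O)N2CCCC[C@H]2c2cc3nc(N4CC[C@H](N)C4)cc1n3n2`. It has 3-aminopyrrolidin-1-yl in place of 3-(methylamino)azetidin-1-yl on an aromatic carbon.

Going by the values given here, one measured step bears on this change, at the same aromatic carbon. Methylamino in place of hydroxy on a saturated ring carbon gave a 1.4-fold lower number from compound 1 to compound 2 (0.13 log units; within the scatter), which stays within the scatter. Among the compounds with values here, no measured step exchanges the four-membered ring for a five-membered one, so that step is only a loose guide. On the strength of it, no shift beyond the scatter is expected in this assay, and no direction can be assigned with confidence.

The estimated step is a 1.1-fold lower number from compound 2 to compound 3 (0.03 log units; within the scatter). For compound 3 the expected value is 5.5 10^-6 cm/s, with an estimated range of 2.2 10^-6 cm/s to 11 10^-6 cm/s.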

Compound 3, apparent permeability: 0.3 10^-6 cm/s
For compound 3 the middle estimate is 18-fold (1.26 log units) above the measured one; the measured number lies below the stated range.
By their numbers in this assay, from the lowest: compound 3; then compounds 2 and 1 (each within the scatter of the next).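

In this assay, the aromatic carbon next to the ring nitrogen proves sensitive to the group it carries: methylamino in place of hydroxy had stayed within the scatter, but 3-aminopyrrolidin-1-yl in place of 3-(methylamino)azetidin-1-yl gives a 20-fold lower number from compound 2 to compound 3 (1.29 log units; beyond the scatter). Set against the hydroxy compound, the result is similar, with a 27-fold lower number from compound 1 to compound 3 (1.43 log units; beyond the scatter), so compound 1 and compound 2, which lie within the scatter of each other, both stand well clear of compound 3. The groups exchanged between compound 2 and compound 3 have the same heavy atoms, hydrogen-bond donors and hydrogen-bond acceptors, so these counts do not separate them; the difference lies in how the atoms are joined, with a five-membered ring in place of a four-membered one, an amino group in place of methylamino, and a defined stereocentre.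

The compounds shown leave open whether the ring size or the amino group goes with the lower number, a question that 3-aminoazetidin-1-yl or 3-(methylamino)pyrrolidin-1-yl at the same carbon would address. They also leave open what the opposite stereoisomer of 3-aminopyrrolidin-1-yl would give, and no measurement at hand accounts for the drop seen with compound 3.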